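A few compounds are considered here, and "the series" means these few. Any claim that something is new, unique, unknown or untested is made for them only; others in the source may bear on it.

The series shares one core, a urea linking a substituted phenyl ring to a chiral phenylethyl group; the substituent on the phenyl ring is what varies. Compound 1 `CC(C)c1ccc(NC(=O)N[C@H](C)c2ccccc2)cc1` carries isopropyl, compound 2 `CCCc1ccc(NC(=O)N[C@H](C)c2ccccc2)cc1` carries propyl, and compound 3 `CCOC(=O)c1ccc(NC(=O)N[C@H](C)c2ccccc2)cc1` carries ethoxycarbonyl. In an ADME assay on the whole organism with Oryza sativa as the target, tested at 0.1 uM (on this read-out higher numbers stand for a weaker effect at the one concentration tested and lower numbers for a stronger effect), compound 1 gives 99%, compound 2 gives 33%, and compound 3 gives 101%. Compound 3 therefore sits at the top of the three numbers: its nearest neighbour is compound 1, with a number 2 percentage points higher from compound 1 to compound 3 (within the scatter), and its furthest is compound 2, with a number 68 percentage points higher from compound 2 to compound 3 (beyond the scatter).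

Compound 4 `C[C@@H](NC(=O)Nc1ccc(Br)cc1)c1ccccc1` is not yet measured. Its change from compound 3 is bromo in place of ethoxycarbonyl on an aromatic carbon. For the measured compounds named here, no measured step introduces bromo, so the bearing steps are indirect: a number 2 percentage points higher from compound 1 to compound 3 (within the scatter) was small, while a number 66 percentage points lower from compound 1 to compound 2 (beyond the scatter) was large. Two of three substituents left the read-out near its ceiling, only propyl lowered it. A step of a number 21 percentage points lower from compound 3 to compound 4 (beyond the scatter) is expected, with wide uncertainty. Compound 4 is estimated at 80%, in the range 35% to 105%.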

Compound 4, a percentage reported as activity, at one concentration (the size of the read-out at that concentration, not a potency): 100%
Beside the measured number, compound 4's estimate is 20 percentage points below it; the measured number falls inside the stated range.
By their numbers in this assay, from the lowest: compound 2; then compounds 1, 4 and 3 (each within the scatter of the next).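

In this assay the position tolerates a sharp change in the substituent: five heavy atoms with two hydrogen-bond acceptors give way to a single bromine atom with none, yet the result is a number 1 percentage points lower from compound 3 to compound 4 (within the scatter) and, against the branched group, a number 1 percentage points higher from compound 1 to compound 4 (within the scatter). Three quite different groups, isopropyl, ethoxycarbonyl and bromo, now give matching numbers, so propyl alone goes against this pattern, as a number 67 percentage points higher from compound 2 to compound 4 (beyond the scatter) shows. No available evidence accounts for the separation of propyl from the other three groups.

The compounds shown leave open whether a longer chain such as butyl would follow propyl, and whether an amine or a carboxylic acid at this position would follow the other three groups. As far as these compounds go, with one concentration tested, how these compounds compare in potency also remains open.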